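Swapping Methoxyphenyl for Dichlorophenyl: Cytotoxicity Outlook

A few compounds are considered here, and "the series" means these few. Any claim that something is new, unique, unknown or untested is made for them only; others in the source may bear on it.

Two measured compounds share one core and differ in a single group. Compound 1 `Cc1ccc(C(=O)Nc2cc(Cl)ccc2OCC(=O)Nc2ccc(S(N)(=O)=O)cc2C)cc1` carries a methyl on an aromatic carbon, while compound 2 `COc1ccc(C(=O)Nc2cc(Cl)ccc2OCC(=O)Nc2ccc(S(N)(=O)=O)cc2C)cc1` carries a methoxy in its place. In a functional assay on C8166 cells (Homo sapiens) for cytotoxicity, read by MTT assay (on this read-out lower numbers stand for higher toxicity in this test and higher numbers for lower toxicity in this test), compound 1 gives 54200 nM, and compound 2 gives 69500 nM. Compound 2 holds the higher of these two numbers, but the step of a 1.3-fold higher number from compound 1 to compound 2 (0.11 log units; within the scatter) is within the scatter, so the two values cannot be told apart.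

Compound 3 `Cc1cc(S(N)(=O)=O)ccc1NC(=O)COc1ccc(Cl)cc1NC(=O)c1ccc(Cl)c(Cl)c1` is not yet measured. It differs from compound 2 by 3,4-dichlorophenyl in place of 4-methoxyphenyl on a carbonyl carbon. Going by the values given here, the only measured step, a 1.3-fold higher number from compound 1 to compound 2 (0.11 log units; within the scatter), changes a group on an aromatic carbon, not the group on the carbonyl carbon, so it does not bear directly on this change; it merely shows that one small swap elsewhere left this assay unmoved. With no closer guide, compound 3 is expected to stay near compound 2 in this assay, and the estimated step is a 1.3-fold lower number from compound 2 to compound 3 (0.10 log units; within the scatter), with no direction beyond the scatter claimed. Compound 3 is therefore estimated at 55000 nM, with a range from 22000 nM to 140000 nM.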

Compound 3, half-maximal cytotoxic concentration: 158000 nM
Estimate against measurement, compound 3: 2.9-fold (0.46 log units) below; measured number outside the range, above it.
By their numbers in this assay, from the lowest: compounds 1 and 2 (each within the scatter of the next); then compound 3.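

Going by these compounds alone, the group on the carbonyl carbon, whose other neighbour is an amide-type nitrogen, is the first place where this assay moves beyond the scatter: 3,4-dichlorophenyl in place of 4-methoxyphenyl gives a 2.3-fold higher number from compound 2 to compound 3 (0.36 log units; beyond the scatter), and 3,4-dichlorophenyl in place of 4-methylphenyl gives a 2.9-fold higher number from compound 1 to compound 3 (0.46 log units; beyond the scatter). Both steps are modest and point towards lower toxicity in this test, and the first of them keeps the six-membered aromatic ring and the number of heavy atoms while the single hydrogen-bond acceptor of the 4-methoxyphenyl group is lost. Nothing available here explains this shift.

The compounds shown leave open whether both chlorines are needed for the higher number, a question that 4-chlorophenyl and 3-chlorophenyl on the same carbonyl carbon would separate. They also leave open how this assay would read with a different kind of group in this place, such as 4-aminophenyl, 4-carboxyphenyl or an open carbon chain in place of the aromatic ring.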